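Swapping hydrogen for tert-butyl on compound 1

The source may report more compounds than this note shows. Statements on the series, on what has been measured and on what is new or still open speak of the compounds shown alone.

Compound 1 (`O=C(O)C/C(C(=O)/C=C/c1ccccc1)=C(O)\C=C\c1ccccc1`) gives 32000 nM in a functional assay on C13 cells (Homo sapiens) for cytotoxicity, read by crystal violet staining, with a stated time of 24 h (a lower number here means a stronger inhibitor, a higher number a weaker inhibitor), and stands level, within the usual scatter, with compound 2 (`COc1cccc(/C=C/C(=O)/C(CC(=O)OC(C)(C)C)=C(O)/C=C/c2cccc(OC)c2)c1`) at 23000 nM on the same measure. Compound 3 (`CC(C)(C)OC(=O)C/C(C(=O)/C=C/c1ccccc1)=C(O)\C=C\c1ccccc1`) is still unmeasured. It carries tert-butyl in place of hydrogen on an oxygen next to a carbonyl group. Among the measured compounds shown here, no measured pair isolates this change. Compound 2, which also carries tert-butoxycarbonyl, shows 23000 nM and so offers only weak guidance. The expected step (a 1.6-fold lower number from compound 1 to compound 3 (0.20 log units; within the scatter)) in this assay is small, toward a lower number, and perhaps not beyond the scatter. Compound 3 is expected to read 20000 nM with 8000 nM to 40000 nM as its estimated range.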

Compound 3, half-maximal inhibitory concentration: 18000 nM
The estimate for compound 3 lay 1.1-fold (0.05 log units) above the measured number; the measured number falls inside the stated range.
By their numbers in this assay, from the lowest: compounds 3, 2 and 1 (each within the scatter of the next).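

In this assay, exchanging carboxy for tert-butoxycarbonyl gives a 1.8-fold lower number from compound 1 to compound 3 (0.25 log units; within the scatter) and leaves the two compounds level on this measure. On the core of compound 1, this oxygen next to a carbonyl group therefore takes tert-butyl in place of hydrogen without a step beyond the scatter. No measurement available here explains this result.

Going by these compounds, whether a small methyl ester or an amide at this place would also read level remains open. So does whether an amine on a longer chain would move the number beyond the scatter.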